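This account rests on a few compounds, and the source may have more. Where it says the series, first, only, none or still open, it means among the compounds named here.

Measured so far:
- compound 1, `Cc1cc(NC(=O)Nc2cccc(C(N)=O)c2)c2ccccc2n1`: 100 nM
- compound 2, `COc1ccc(NC(=O)Nc2cc(C)nc3ccccc23)cc1OC`: 4100 nM

Of the compounds shown here, two have been measured in a physicochemical assay for solubility, at pH 7.4; on this read-out higher numbers stand for higher solubility and lower numbers for lower solubility. Compound 2 holds the higher of the two numbers, and compound 1 the lower; the gap between them is well beyond the usual scatter of repeated measurements. For the measured compounds named here, no pair of measured compounds differs in only one place, so no single step can be read from them.

Compound 3, `COc1cccc(NC(=O)Nc2cc(C)nc3ccccc23)c1`, has not yet been measured. It differs from compound 2 in one place: hydrogen in place of methoxy on an aromatic carbon. Going by the values given here, nothing among the measured compounds shows what this particular change does on this read-out, so the expectation rests on the change being small. The step from compound 2 to compound 3 is expected to be modest, with a slight lean toward a lower number, about a 1.6-fold lower number from compound 2 to compound 3 (0.21 log units; within the scatter), and not beyond the scatter. Compound 3 is therefore expected to give around 2500 nM, within the range 800 nM to 8000 nM.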

Compound 3, solubility: 1200 nM
Compound 3: middle estimate off by 2.1-fold (0.32 log units), on the high side; the range from low to high includes it.
By their numbers in this assay, from the lowest: compound 1; then compound 3; then compound 2.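

In this assay, putting hydrogen in place of methoxy on an aromatic carbon, ortho to a methoxy group and para to a large group, gives a 3.4-fold lower number from compound 2 to compound 3 (0.53 log units; beyond the scatter), so the read-out does respond to a change at this position. Compound 3 also gives the first link in one place to compound 1: methoxy in place of carbamoyl on an aromatic carbon gives a 12-fold higher number from compound 1 to compound 3 (1.08 log units; beyond the scatter), a large step where the other is modest. Nothing measured here explains the direction or size of either step.

Still open, going by these compounds, is whether another group on the carbon that lost the methoxy, such as a hydroxyl, an amine or a carboxylic acid, would give a higher or a lower number. Also open, on these data alone, is what hydrogen in place of the remaining methoxy would do.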